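The compounds below may be only part of what the source reports. "The series", "measured", "known", "first", "only" and "open" are said of these compounds alone.

Measured compounds:
- compound 1 `CCCCCCCCCCCCCCCCCC(=O)N1CCOCC1` — 42.8 ug/mL
- compound 2 `CCCCCCCC/C=C\CCCCCCCC(=O)N1CCCC1` — 5.2 ug/mL

Among the measured compounds shown here, in a functional assay on MCF7 cells (Homo sapiens) for antiproliferative activity, read by sulforhodamine B assay, with a stated time of 48 h (a higher number here means a weaker inhibitor of growth, a lower number a stronger inhibitor of growth), compound 1 gives 42.8 ug/mL, the higher of the two numbers and the only other number, that of compound 2, sits well below it, beyond the scatter. For the measured compounds named here, compound 2 differs from compound 1 in more than one place, so no single step between the two can be read from their values; they show only that the pyrrolidin-1-yl amide with the unsaturated chain inhibits growth more strongly.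

Compound 3 `CCCCCCCCCCCCCCCCCC(=O)N1CCCC1` differs from compound 1 as follows: pyrrolidin-1-yl in place of morpholin-4-yl on a carbonyl carbon. Going by the values given here, no measured pair isolates this change. Since compound 2, which also carries pyrrolidin-1-yl, gives 5.2 ug/mL, the step from compound 1 is expected to go downward, beyond the scatter, as a 2.9-fold lower number from compound 1 to compound 3 (0.46 log units; beyond the scatter). Compound 3 is accordingly expected to give 15 ug/mL, with a range from 5 ug/mL to 45 ug/mL.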

Compound 3, concentration for 50% growth inhibition: 7.4 ug/mL
The estimate for compound 3 lay 2.0-fold (0.31 log units) above the measured number; the range from low to high includes it.
By their numbers in this assay, from the lowest: compounds 2 and 3 (each within the scatter of the next); then compound 1.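

With the saturated chain held fixed, pyrrolidin-1-yl in place of morpholin-4-yl on a carbonyl carbon gives a 5.8-fold lower number from compound 1 to compound 3 (0.76 log units; beyond the scatter) in this assay, so this change alone accounts for a step beyond the scatter. The earlier pair could not show this, as its members differ in more than one place. Compound 3 at 7.4 ug/mL and compound 2 at 5.2 ug/mL lie within the scatter of each other, so these two values separate the saturated chain from the unsaturated one by nothing beyond the scatter.

A piperidin-1-yl amide on the same chain would separate the change in ring size from the loss of the ring oxygen. From the compounds shown here alone, the effect of a shorter chain on the pyrrolidin-1-yl amide also remains open. No measurement at hand explains the size of this step.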